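From Nitro to Chloro in a Thinly Measured Set

This account rests on a few compounds, and the source may have more. Where it says the series, first, only, none or still open, it means among the compounds named here.

In a functional assay on BT-549 cells (Homo sapiens) for cytotoxicity, read by MTT assay, with a stated time of 48 h (a lower number here means a stronger inhibitor, a higher number a weaker inhibitor), only compound 1 (`CC(C)n1c(/C=C2/C(=O)Nc3ccccc32)nc2ccccc21`) carries a number, with a half-maximal inhibitory concentration of 38900 nM on these cells. Compound 2 (`Cn1c(/C=C2/C(=O)Nc3ccc([N+](=O)[O-])cc32)nc2ccccc21`) stands without a number, its entry reading "not determined" (no result reported) and so it cannot be placed against compound 1. Compound 3 (`CCn1c(/C=C2/C(=O)Nc3ccc(Br)cc32)nc2ccccc21`) is in the same position, reading "not determined" (no result reported) with nothing to compare. The compound awaiting measurement is compound 4 (`Cn1c(/C=C2/C(=O)Nc3ccc(Cl)cc32)nc2ccccc21`) on the shared core. Within the data shown here, the single change leading to it (chloro in place of nitro on an aromatic carbon) is chloro in place of nitro on an aromatic carbon. Among the measured compounds shown here, no measured step in this set shows what such a change does, so no step beyond the scatter is expected away from the one available anchor, which is compound 1 at 38900 nM in this small set. In this assay compound 4 is expected at 25000 nM within an estimated range of 7000 nM to 80000 nM as a working figure.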

Compound 4, half-maximal inhibitory concentration: 39100 nM
The estimate for compound 4 lay 1.6-fold (0.19 log units) below the measured number, within the range that was stated.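

In this assay compound 4 gives 39100 nM, but no step can be read from it, as compound 2 has no single number to set against it. On these data alone, what chloro in place of nitro does on these cells stays open, and no supporting evidence bears on the result.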